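Adding a Second Trifluoromethyl to the Urea Aryl Group

The source may hold more compounds than are shown below. What is called first, only, known or untested is meant among the compounds shown, and "the series" means these compounds.

For the measured compounds named here, compound 1 `O=C(Nc1cccc(-n2cc(-c3ccncc3)c(-c3ccc(Cl)c(O)c3)n2)c1)Nc1cccc(C(F)(F)F)c1` gives 2020 nM in a functional assay on SK-MEL-2 cells (Homo sapiens) for inhibition, read by sulforhodamine B assay, with a stated time of 48 h (on this read-out lower numbers stand for stronger inhibition of growth and higher numbers for weaker inhibition of growth), the highest of the three numbers measured so far. Compound 2 `O=C(Nc1cccc(-n2cc(-c3ccncc3)c(-c3ccc(Cl)c(O)c3)n2)c1)Nc1ccc(Cl)c(Cl)c1` gives 1030 nM in this assay, and compound 3 `COc1cc(-c2nn(-c3cccc(NC(=O)Nc4cccc(C(F)(F)F)c4)c3)cc2-c2ccncc2)ccc1Cl` gives 970 nM. Compound 4 `O=C(Nc1cccc(-n2cc(-c3ccncc3)c(-c3ccc(Cl)c(O)c3)n2)c1)Nc1cc(C(F)(F)F)cc(C(F)(F)F)c1` differs from compound 1 by trifluoromethyl in place of hydrogen on an aromatic carbon. The step that bears on this change is the one on the same aryl group, a 2.0-fold lower number from compound 1 to compound 2 (0.29 log units; within the scatter), a small shift. The other measured change, a 2.1-fold lower number from compound 1 to compound 3 (0.32 log units; beyond the scatter), sits on a different ring and says nothing about this position. A second trifluoromethyl is therefore expected to move the number little, if at all. Compound 4 is estimated at 1400 nM, within 500 nM to 4000 nM, which would mean a 1.4-fold lower number from compound 1 to compound 4 (0.16 log units; within the scatter).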

Compound 4, concentration for 50% growth inhibition: 1250 nM
For compound 4 the middle estimate is 1.1-fold (0.05 log units) above the measured one; the measured number falls inside the stated range.
By their numbers in this assay, from the lowest: compounds 3, 2, 4 and 1 (each within the scatter of the next, the first and the last beyond it).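

In this assay the second trifluoromethyl brings a 1.6-fold lower number from compound 1 to compound 4 (0.21 log units; within the scatter) and so leaves the number unchanged within the scatter. This aromatic carbon, meta to the first trifluoromethyl group, therefore carries four more heavy atoms without a clear loss or gain in growth inhibition. No measurement shown explains this result.

An amine or a carboxylic acid at this same place could move the number or leave it where it is. On these data alone, it also remains open whether a second trifluoromethyl would give the same result on compound 3.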